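The compounds below may be only part of what the source reports. "The series", "measured", "known", "first", "only" and "open" are said of these compounds alone.

- compound 1 `O=C(Cn1cc(CO)nn1)NCc1ccccc1` gives 490 uM
- compound 2 `CCC(O)Cc1cn(CC(=O)NCc2ccccc2)nn1` gives 630 uM

Within the data shown here, in an ADME assay on cells (spleen, Mus musculus, strain C57BL/6) for inhibition, read by flow cytometry and propidium iodide staining, with a stated time of 24 h, at 37 degrees C (on this read-out lower numbers stand for an effect already at smaller amounts and higher numbers for an effect only at larger amounts of compound), compound 2 (630 uM) cannot be told apart from compound 1, so it stands level with the only other measured compound. Compound 3 `O=C(Cn1cc(CCCCO)nn1)NCc1ccccc1` holds the same atoms as compound 2, joined differently, as 3-hydroxypropyl in place of 1-hydroxypropyl on a saturated chain carbon bound to an aromatic carbon shows. Among the measured compounds shown here, one measured step bears on this place on the chain, and it is a 1.3-fold higher number from compound 1 to compound 2 (0.11 log units; within the scatter) so far. For the measured compounds named here, that step stayed small, but no measured pair tests moving the hydroxy group along the chain, which leaves the expectation resting on one small step. No clear direction is expected, and the estimated change, a 1.1-fold lower number from compound 2 to compound 3 (0.05 log units; within the scatter), is expected to stay within the scatter. For compound 3 the estimated value is 560 uM with an expected range from 280 uM to 1100 uM in this read-out.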

Compound 3, concentration for half-maximal effect: 1700 uM
Compound 3: the middle estimate sits 3.0-fold (0.48 log units) below what was measured; the measured number lies above the stated range.
By their numbers in this assay, from the lowest: compounds 1 and 2 (each within the scatter of the next); then compound 3.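

In this assay, among these compounds, the same atoms arranged differently on a saturated chain carbon bound to an aromatic carbon no longer give a level result: 3-hydroxypropyl in place of 1-hydroxypropyl gives a 2.7-fold higher number from compound 2 to compound 3 (0.43 log units; beyond the scatter), the first step beyond the scatter, although the counts of heavy atoms, donors and acceptors do not change. Hydroxy replaced by 3-hydroxypropyl also moves the number beyond the scatter, with a 3.5-fold higher number from compound 1 to compound 3 (0.54 log units; beyond the scatter), so the series now separates into a level pair and one compound with a higher number. Nothing available accounts for this shift.

The compounds shown leave open whether a longer chain would continue this direction. They also leave open whether an amine or a carboxylic acid in place of the hydroxy group on the 3-hydroxypropyl chain would keep the higher number.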